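This account rests on a few compounds, and the source may have more. Where it says the series, first, only, none or still open, it means among the compounds named here.

In a functional assay on HL-60 cells (Homo sapiens), read by calcium flux (a lower number here means that less compound is needed, a higher number that more compound is needed for the effect), compound 1 `Cc1cc(Cc2cccc(Cl)c2)c(=O)n(CC(=O)Nc2ccc(Br)cc2)n1` gives > 50000 nM, which is a limit of the assay and not a number. Compound 2 `COc1cc(Cc2cc(C)nn(CC(=O)Nc3ccc(Br)cc3)c2=O)cc(OC)c1` gives > 50000 nM, which is also a limit. Within the data shown here, compound 1 therefore has no exact position on the scale, and the only evidence so far is the limit of > 50000 nM in this assay, at which 2 of the 2 values shown sit.

Compound 3 `Cc1cc(N)c(=O)n(CC(=O)Nc2ccc(Br)cc2)n1` has amino in place of the 3-chlorobenzyl of compound 1, on an aromatic carbon opposite the ring nitrogen (amino in place of 3-chlorobenzyl on an aromatic carbon). Among the measured compounds shown here, this change removes the whole 3-chlorobenzyl group, whereas the one measured step keeps the saturated chain carbon and alters only the aromatic ring attached to it. That step, a step that the two limits leave unreadable from compound 1 to compound 2, puts 3,5-dimethoxyphenyl in place of 3-chlorophenyl and gives no size to carry over.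

In this assay, the expectation is therefore a modest step toward a lower number, if there is any step at all. The expected at least 1.6-fold lower number from compound 1 to compound 3 (0.22 log units; that floor lies within the scatter) is only a rough estimate, as it starts from a limit. The estimated value for compound 3 is 30000 nM, with an expected range from 6000 nM to 50000 nM.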

Compound 3, half-maximal effective concentration: > 50000 nM
Compound 3: only a limit was reported; the forecaster's own chance of this, stated with the estimate: 70%; middle value at least 1.6-fold (0.22 log units) away from the limit.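

Compound 3 gives > 50000 nM in this assay, which is a limit of the assay and not a number. Among these compounds, compound 1 also stands at a limit, so no step between compound 1 and compound 3 can be read: the limit of > 50000 nM in this assay, at which 3 of the 3 values shown sit. The compounds shown leave open which change to the shared core, if any, would give a measurable value in this assay.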